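From cyclopropylmethoxy to ethoxy under a clearance limit

A few compounds are considered here, and "the series" means these few. Any claim that something is new, unique, unknown or untested is made for them only; others in the source may bear on it.

Three compounds measured so far in an ADME assay on microsomes from liver (Mus musculus) for metabolic stability (on this read-out lower numbers stand for slow clearance and higher numbers for fast clearance), each reported only as a limit:
- compound 1 `CCOc1cc2[nH]c(Cc3nn(CC(=O)O)c(=O)c4ccccc34)nc2cc1Cl` with < 51.7 mL/min/kg as its limit
- compound 2 `O=C(O)Cn1nc(Cn2cc3cc(OCC4CC4)c(Cl)cc3n2)c2ccccc2c1=O` with < 85 mL/min/kg as its limit
- compound 3 `C[C@H](C(=O)O)n1nc(Cn2cc3cc(OCC4CC4)c(Cl)cc3n2)c2ccccc2c1=O` with < 66.7 mL/min/kg as its limit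

For compound 2, < 85 mL/min/kg is a limit of the assay and not a number. The other two readings are also limits, so compound 2 has no exact place among them.

Compound 4 `CCOc1cc2cn(Cc3nn(CC(=O)O)c(=O)c4ccccc34)nc2cc1Cl` differs from compound 2 by methyl in place of cyclopropyl on a saturated chain carbon bound to an oxygen on an aromatic ring in one place: methyl in place of cyclopropyl on a saturated chain carbon bound to an oxygen on an aromatic ring. Cyclopropylmethoxy thus becomes ethoxy.

Within the data shown here, the one measured step is a step that the two limits leave unreadable from compound 2 to compound 3 and it is a different change, so it offers no size to carry over. Compound 1 also carries ethoxy, and < 51.7 mL/min/kg is again a limit.

With no readable step, no change beyond the usual scatter is expected in this assay, and no direction can be named. The expected move is a step that the limit leaves unreadable from compound 2 to compound 4 and it remains an estimate. Compound 4 is expected at 45 mL/min/kg within an estimated range of 18 mL/min/kg to 85 mL/min/kg in this measurement.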

Compound 4, clearance: 107 mL/min/kg
Compound 4: the middle estimate sits 2.4-fold (0.38 log units) below what was measured; measured number outside the range, above it.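

Compound 4 gives the only exact number among the compounds shown in this assay, so a clearance can now be read for a compound carrying ethoxy on this core. Replacing cyclopropylmethoxy with ethoxy gives an at least 1.2-fold higher number from compound 2 to compound 4 (0.09 log units; that floor lies within the scatter), so the printed direction is upward, but the smallest step allowed does not by itself separate this change from ordinary scatter. The true size stays unknown because compound 2 is known only through a limit of the assay: the limit of < 85 mL/min/kg in this assay, at which 1 of the 4 values shown sits.

The step that links the two compounds known only by limits cannot be read, so it gives no size to set against this one. As far as these compounds go, it also remains open how clearance would respond to methoxy or to a longer chain such as propoxy in this place.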